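Cinnamoyl for Thiophenecarbonyl on a Threonine Octylamide

A few compounds are considered here, and "the series" means these few. Any claim that something is new, unique, unknown or untested is made for them only; others in the source may bear on it.

The compounds measured so far, with their numbers in a functional assay on SiHa cells (Homo sapiens) for cytotoxicity, read by MTT assay, with a stated time of 48 h; on this read-out higher numbers stand for weaker inhibition and lower numbers for stronger inhibition:
compound 1 `CCCCCCCCCCCCCCCCCCNC(=O)[C@@H](N)[C@@H](C)O`: compound 1 gives 39500 nM
compound 2 `CCCCCCCCNC(=O)[C@@H](NC(=O)c1ccccc1)[C@@H](C)O`: compound 2 gives 112000 nM
compound 3 `CCCCCCCCNC(=O)[C@@H](NC(=O)c1cccs1)[C@@H](C)O`: compound 3 gives 91900 nM

Compound 3 stands second highest of the three numbers in this assay. Its nearest neighbour is compound 2, whose number lies within the scatter of it, so no order between the two can be claimed. Its furthest neighbour is compound 1, whose number is lower by a margin beyond the scatter.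

The next compound, compound 4 `CCCCCCCCNC(=O)[C@@H](NC(=O)/C=C/c1ccccc1)[C@@H](C)O`, differs from compound 3 in one place: 2-phenylethenyl in place of thiophen-2-yl on a carbonyl carbon. Among the measured compounds shown here, only one measured step bears on this kind of exchange at the carbonyl carbon, namely a 1.2-fold lower number from compound 2 to compound 3 (0.09 log units; within the scatter). That step stayed within the scatter, so an exchange of the acyl aromatic group has so far left the number essentially unchanged. Nothing in the measured set speaks for a shift in either direction for the 2-phenylethenyl group, and no step beyond the scatter is therefore expected.

For compound 4 the number in this assay is expected to be 85000 nM, with a range from 35000 nM to 200000 nM. The step expected is a 1.1-fold lower number from compound 3 to compound 4 (0.03 log units; within the scatter).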

Compound 4, half-maximal inhibitory concentration: 41400 nM
Estimate against measurement, compound 4: 2.1-fold (0.31 log units) above; the measured number falls inside the stated range.
By their numbers in this assay, from the lowest: compounds 1 and 4 (each within the scatter of the next); then compounds 3 and 2 (each within the scatter of the next).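

In this assay, the earlier exchange at this carbonyl carbon, a 1.2-fold lower number from compound 2 to compound 3 (0.09 log units; within the scatter), had left the number essentially unchanged, so the place could have seemed indifferent to the group it carries. Among the compounds shown here, the 2-phenylethenyl group changes that picture, with a 2.2-fold lower number from compound 3 to compound 4 (0.35 log units; beyond the scatter) and a 2.7-fold lower number from compound 2 to compound 4 (0.43 log units; beyond the scatter), both modest but beyond the scatter, and these are the first exchanges at this place to reach that size. The data shown include no measurement that could account for the shift, so it stands as an observation about these three compounds only.

What the compounds shown leave open is whether a saturated 2-phenylethyl group on the same carbonyl carbon would give a similar number, which would separate the part played by the double bond from that of the two added carbons. Also open, as far as these compounds go, is whether a methoxy group or a chlorine on the phenyl ring of the 2-phenylethenyl group, or a longer chain in place of the octyl chain, would move the number further in either direction.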